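Oxime for acetyl on the aryl amide: one step, two cores

A few compounds are considered here, and "the series" means these few. Any claim that something is new, unique, unknown or untested is made for them only; others in the source may bear on it.

Of the compounds shown here, three have been measured in a functional assay on the whole organism (strain albino) for inhibition, with Rattus norvegicus as the target, read by paw edema, with stated times of 30 min and 3 h, at a dose of 0.28 mmol/kg by the oral route; a lower number here means less inhibition, a higher number more inhibition at the dose given (going by the name of the read-out). Compound 3 `CCn1c(SCC(=O)Nc2ccc(C(C)=O)cc2)nnc1-c1cc(OC)c(OC)c(OC)c1` gives 54%. Compound 1 `CCn1c(SCC(=O)Nc2ccc(/C(C)=N/O)cc2)nnc1-c1cc(OC)c(OC)c(OC)c1` carries the oxime in place of the acetyl and gives 70%; the change is a group of 4 heavy atoms (2 carbon, 1 nitrogen, 1 oxygen; no ring) in place of a group of 3 heavy atoms (2 carbon, 1 oxygen; no ring), on an aromatic carbon and the step is a number 16 percentage points higher from compound 3 to compound 1 (beyond the scatter). Compound 2 `C=CCn1c(SCC(=O)Nc2ccc(C(C)=O)cc2)nnc1-c1ccc(OC)c(OC)c1`, on a different core, gives 58%; the difference between the cores of compound 2 and compound 3 is not broken down here, and the values of the two lie within the scatter of each other.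

Compound 4 `C=CCn1c(SCC(=O)Nc2ccc(/C(C)=N/O)cc2)nnc1-c1ccc(OC)c(OC)c1` is not yet measured. It stands to compound 2 as compound 1 stands to compound 3: the change is a group of 4 heavy atoms (2 carbon, 1 nitrogen, 1 oxygen; no ring) in place of a group of 3 heavy atoms (2 carbon, 1 oxygen; no ring), on an aromatic carbon, the same change, at the same place. For the measured compounds named here, only one such pair is measured, so the expectation rests on that single step. In this assay the step from compound 2 to compound 4 is expected to be a number 14 percentage points higher from compound 2 to compound 4 (beyond the scatter), because the same change gave a number 16 percentage points higher from compound 3 to compound 1 (beyond the scatter) on the other core. Compound 4 is thus estimated at 72%, with a range of 62% to 82%.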

Compound 4, a percentage reported as inhibition, in the whole organism at one dose (the size of the read-out at that dose, not a potency): 70%
Compound 4: middle estimate off by 2 percentage points, on the high side; the measured number falls inside the stated range.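

In this assay the oxime in place of the acetyl gives a number 12 percentage points higher from compound 2 to compound 4 (beyond the scatter), so the change carries over to the core of compound 2. Set beside the earlier step, the two agree in direction and do not separate in size: the same change on two cores in this assay, a number 16 percentage points higher (beyond the scatter) from compound 3 to compound 1 and a number 12 percentage points higher (beyond the scatter) from compound 2 to compound 4, 4 percentage points apart, within the scatter of two such steps. This rests on a single pair on each of two cores, at one dose and with one read-out, so it does not show that the step would hold on any further core, and it says nothing about how the oxime produces the change.

The compounds shown leave open whether another group at this place on the aromatic ring, such as an amine, a carboxylic acid or a nitrile, would match the oxime. Also open, on these data alone, are how the methyl ether of the oxime would compare with the oxime itself, and whether the step would survive a longer chain in place of the ethyl or allyl group on the core.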